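Working notes: pyridinyl swap on the compound 3 side chain

A few compounds are considered here, and "the series" means these few. Any claim that something is new, unique, unknown or untested is made for them only; others in the source may bear on it.

Values in a functional assay on A-375 cells (Homo sapiens) for activation, with a stated time of 3 days; a higher number here means that more compound is needed for the effect, a lower number that less compound is needed:
- compound 1 `O=C(Nc1ccc(-c2cscn2)cc1)C1CCN(Cc2ccc(F)c(F)c2)CC1`: 19000 nM
- compound 2 `O=C(Nc1ccc(-c2cscn2)cc1)C1CCCN(S(=O)(=O)c2ccc(F)c(F)c2)C1`: > 20000 nM (a limit of the assay, not a number)
- compound 3 `O=C(Nc1ccc(-c2cscn2)cc1)C1CCCN(Cc2ccc(F)cc2)C1`: 5000 nM

Compound 3 carries the lower of the two actual numbers, at 5000 nM. Compound 1 gives 19000 nM. The gap between compound 1 and compound 3 lies beyond the scatter. Compound 2 reports only a limit, > 20000 nM.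

Compound 4 `O=C(Nc1ccc(-c2cscn2)cc1)C1CCCN(Cc2cccnc2)C1` has not yet been measured. It differs from compound 3 as follows: pyridin-3-yl in place of 4-fluorophenyl on a saturated chain carbon bound to an amine nitrogen in a ring. In words, pyridin-3-yl stands in place of 4-fluorophenyl on a saturated chain carbon bound to an amine nitrogen in a ring; cut one bond further out, this reads 4-fluorobenzyl to (pyridin-3-yl)methyl.

Within the data shown here, no two measured compounds differ in one place only, so no direct precedent sizes this step. Among the measured compounds shown here, a modest step towards a higher number in this assay is expected, since compound 3 at 5000 nM holds the lowest number so far and a change from there is more likely to raise it than to lower it. The expected step is a 2.2-fold higher number from compound 3 to compound 4 (0.34 log units; beyond the scatter). For compound 4 the estimated value is 11000 nM, with an expected range of 4500 nM to 25000 nM.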

Compound 4, half-maximal effective concentration: > 20000 nM
Compound 4 was reported as a limit; the forecaster's own chance of this, stated with the estimate: 30%; middle value at least 1.8-fold (0.25 log units) away from the limit.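

In this assay, among these compounds, pyridin-3-yl in place of 4-fluorophenyl on a saturated chain carbon bound to an amine nitrogen in a ring gives the only step with a single place changed: an at least 4.0-fold higher number from compound 3 to compound 4 (0.60 log units; beyond the scatter). Compound 1 and compound 2 could not show this, as each differs from compound 3 in more than one place; here, a ring of carbon only bearing fluorine gives way to a ring with one hetero atom and one hydrogen-bond acceptor, and the number goes up. The step is only a lower bound, and its full size stays unknown because the value of compound 4 is a limit of the assay and not a number: the limit of > 20000 nM in this assay, at which 2 of the 4 values shown sit.

The swap removes the fluorine and brings in the ring nitrogen together, and the compounds shown do not separate the two; a benzyl group without fluorine in the same place would do so. Also open, on these data alone, is how a 4-chlorobenzyl group or a (pyridin-4-yl)methyl group in that place would compare with compound 3.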